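Aryl exchange on the dienone chain of compound 2

This account rests on a few compounds, and the source may have more. Where it says the series, first, only, none or still open, it means among the compounds named here.

Measured so far in a functional assay on PC-3 cells (Homo sapiens) for cytotoxicity, read by MTT assay, with a stated time of 72 h; on this read-out lower numbers stand for stronger inhibition and higher numbers for weaker inhibition:
compound 1 `CC1=C(/C=C/C(=O)/C=C/c2ccccc2F)C(C)(C)CCC1`: 22100 nM
compound 2 `CC1=C(/C=C/C(=O)/C=C/c2ccc(F)cc2)C(C)(C)CCC1`: 25800 nM

Compound 2 holds the highest of the two numbers in this assay; its nearest neighbour is compound 1, and the step of a 1.2-fold higher number from compound 1 to compound 2 (0.07 log units; within the scatter) lies within the scatter. Compound 3 `CC1=C(/C=C/C(=O)/C=C/c2cccc(C)c2)C(C)(C)CCC1` differs from compound 2 by 3-methylphenyl in place of 4-fluorophenyl on a double-bonded chain carbon bound to a double-bonded chain carbon. Among the measured compounds shown here, the only measured step, a 1.2-fold higher number from compound 1 to compound 2 (0.07 log units; within the scatter), exchanges one fluorophenyl for another and stays within the scatter; no measured step replaces fluorine by methyl. No step beyond the scatter is therefore expected. Compound 3 is estimated at 24000 nM, range 8000 nM to 70000 nM, an expected step of a 1.1-fold lower number from compound 2 to compound 3 (0.03 log units; within the scatter).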

Compound 3, half-maximal inhibitory concentration: 35000 nM
Compound 3: the middle estimate sits 1.5-fold (0.16 log units) below what was measured; the range from low to high includes it.
By their numbers in this assay, from the lowest: compounds 1, 2 and 3 (each within the scatter of the next).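

In this assay the steps to 3-methylphenyl (a 1.4-fold higher number from compound 2 to compound 3 (0.13 log units; within the scatter) and a 1.6-fold higher number from compound 1 to compound 3 (0.20 log units; within the scatter)) stay within the scatter. At this chain carbon, a methyl-bearing phenyl therefore reads the same as either fluorophenyl, so the exchange now extends beyond moving fluorine around the ring without separating the three compounds. No measurement on hand accounts for these numbers.

Still open, from the compounds shown here alone, is whether any group at this position gives a step beyond the scatter, for example an amine or a carboxylic acid on the phenyl ring. The compounds shown also leave open what a longer chain in place of the phenyl would do.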